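This account rests on a few compounds, and the source may have more. Where it says the series, first, only, none or still open, it means among the compounds named here.

In a functional assay on B16-F10 cells (Mus musculus) for antiproliferative activity, read by MTT assay, with a stated time of 72 h (on this read-out higher numbers stand for weaker inhibition and lower numbers for stronger inhibition), compound 2 (`CCCCCCCCCCCCCCNC[C@@H]1OC[C@H](N)[C@H]1O`) gives 64300 nM, the higher of the two actual numbers in the series. Compound 3 (`CCCCCCCCCCCCNC[C@@H]1OC[C@H](N)[C@@H]1O`) gives 10700 nM, lower than compound 2 by more than the scatter. Compound 1 (`CCCCCCCCCNC[C@@H]1OC[C@H](N)[C@H]1O`) gives > 128000 nM, which is a limit and not a number.

Compound 4 (`CCCCCCCCNC[C@@H]1OC[C@H](N)[C@H]1O`) is still unmeasured. It differs from compound 2 by hydrogen in place of hexyl on a saturated chain carbon, eight bonds along the chain from an amine nitrogen.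

For the measured compounds named here, the one measured step that bears on this is an at least 1.9-fold lower number from compound 1 to compound 2 (0.29 log units; that floor lies within the scatter), with pentyl in place of hydrogen on the chain. On these data alone, its true size stays open, and its floor alone does not clear the scatter. Compound 4 loses hexyl rather than pentyl, so a move to a higher number in this assay is expected, with the limit of > 128000 nM in this assay, at which 1 of the 3 values shown sits, as the nearest reference. The expected change is a 2.5-fold higher number from compound 2 to compound 4 (0.40 log units; beyond the scatter). A report of only a limit is the likelier outcome. Compound 4 is estimated at 160000 nM, within an expected range of 100000 nM to 300000 nM.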

Compound 4, half-maximal inhibitory concentration: > 128000 nM
Compound 4: a limit, no number (the forecaster's own chance of this, stated with the estimate: 80%); the middle value is on the limit's open side.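

In this assay, hydrogen in place of hexyl on a saturated chain carbon, eight bonds along the chain from an amine nitrogen, gives an at least 1.9-fold higher number from compound 2 to compound 4 (0.29 log units; that floor lies within the scatter), so this step, like the earlier at least 1.9-fold lower number from compound 1 to compound 2 (0.29 log units; that floor lies within the scatter), has a floor but no true size. Compound 4 gives a limit and not a number, and the series now has two such values: the limit of > 128000 nM in this assay, at which 2 of the 4 values shown sit. The step between compound 1 and compound 4 cannot be read, so the two chains shorter than that of compound 2 are not ranked against each other.

On these data alone, what a longer chain than that of compound 2 would give on this read-out remains open. Also open, as far as these compounds go, is whether a hydroxyl or a carboxylic acid at the chain end would bring the shorter chains back to a measurable number.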